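Moving One Double Bond From Z to E

This account rests on a few compounds, and the source may have more. Where it says the series, first, only, none or still open, it means among the compounds named here.

Compound 1 `Cc1ccc(/C=C2/C(=O)c3ccccc3OC2c2ccccc2)cc1`: 60100 nM
Compound 2 `O=C1/C(=C\c2ccc(Cl)cc2)C(c2ccccc2)Oc2ccccc21`: 27400 nM

In a functional assay on WM-115 cells (Homo sapiens) for cytotoxicity, read by MTT assay, with a stated time of 46 h (a lower number here means a stronger inhibitor, a higher number a weaker inhibitor), compound 2 gives 27400 nM, the lower of the two numbers and so the stronger result. Compound 1 gives 60100 nM, a gap beyond the usual scatter of repeated measurements.

The next compound to consider is compound 3 `O=C1/C(=C/c2ccc(Cl)cc2)C(c2ccccc2)Oc2ccccc21`, which differs from compound 2 by one change (the two compounds have the same atoms and bonds; at least one stereo element is drawn with a configuration in one of them and without one in the other: 1 of 2 stereo elements differ; a double bond is drawn Z in compound 2 and E in compound 3). The two compounds have the same atoms and bonds, but a double bond is drawn Z in compound 2 and E in compound 3. Within the data shown here, no measured pair shows what such a change does, so the data offer no direct guide to its size. In this assay, on these data alone, the expected step of a 1.3-fold higher number from compound 2 to compound 3 (0.11 log units; within the scatter) stays within the scatter, and its direction remains open. For compound 3 the estimate is 35000 nM, with an expected range of 12000 nM to 90000 nM.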

Compound 3, half-maximal inhibitory concentration in the WM-115 assay: 52000 nM
Beside the measured number, compound 3's estimate is 1.5-fold (0.17 log units) below it; the measured number falls inside the stated range.
By their numbers in the WM-115 assay, from the lowest: compounds 2, 3 and 1 (each within the scatter of the next, the first and the last beyond it).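

In the WM-115 assay, compound 2 gives 27400 nM and compound 3 gives 52000 nM, and turning the double bond from Z to E gives a 1.9-fold higher number from compound 2 to compound 3 (0.28 log units; within the scatter), so at this position the change in geometry alone does not stand clear of the scatter. Also in the WM-115 assay, chloro in place of methyl on an aromatic carbon gives a 1.2-fold lower number from compound 1 to compound 3 (0.06 log units; within the scatter), which means the gap seen earlier between compound 1 and compound 2 is made of two separate changes, neither of them beyond the scatter on its own. In a physicochemical assay for lipophilicity, read by HPLC (a higher number here means a more lipophilic compound, a lower number a more polar compound), compound 2 gives 4.53 and compound 3 gives 4.46, and the same double-bond change gives a number 0.07 log units lower from compound 2 to compound 3 (within the scatter).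

How firmly the double-bond comparison can be read carries a caveat: the fact that one of compounds 2 and 3 is drawn with a defined configuration and the other without, at the place where they differ. On these data alone, whether an amine or a carboxylic acid in place of the chloro would move the number beyond the scatter remains open.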